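The source may report more compounds than this note shows. Statements on the series, on what has been measured and on what is new or still open speak of the compounds shown alone.

Compound 2 `C[C@@H](Oc1cc2onc(CCC(=O)O)c2cc1Cl)c1ccc(Cl)cn1` is the starting point. Going by the values given here, in an assay on HEK293 cells for inhibition of kynurenine 3-monooxygenase (Homo sapiens), read by LC-MS, with a stated time of 20 h (on this read-out lower numbers stand for stronger inhibition and higher numbers for weaker inhibition), compound 2 gives 3.98 nM, the second highest of the three numbers measured so far. Its nearest neighbour is compound 1 `Cc1ccc([C@@H](C)Oc2cc3onc(CCC(=O)O)c3cc2Cl)nc1`, which in this assay gives 1.59 nM; the furthest is compound 3 `C[C@@H](Oc1cc2oc(=O)n(CCC(=O)O)c2cc1Cl)c1ccc(Cl)cn1`, which in this assay gives 100 nM. The step to the new compound 4 `C[C@@H](Oc1cc2onc(CCC(=O)O)c2cc1Cl)c1ccccn1` is hydrogen in place of chloro on an aromatic carbon. Among the compounds with values here, the one measured step that touches this position is the change from compound 1 to compound 2, where chloro in place of methyl on the same aromatic carbon gave a 2.5-fold higher number from compound 1 to compound 2 (0.40 log units; beyond the scatter). Within the data shown here, that step shows that this position matters, but no measured pair shows what happens when the group is taken away altogether, and no further step on this ring exists to support a direction. On that thin basis, compound 4 is expected to land near compound 2 or slightly weaker, with a step of about a 1.6-fold higher number from compound 2 to compound 4 (0.20 log units; within the scatter). Compound 4 is therefore estimated at 6.3 nM in this assay, within the range 2.5 nM to 16 nM.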

Compound 4, half-maximal inhibitory concentration: 3.16 nM
Compound 4: the middle estimate sits 2.0-fold (0.30 log units) above what was measured, and the stated range covers the measured number.
By their numbers in this assay, from the lowest: compounds 1, 4 and 2 (each within the scatter of the next, the first and the last beyond it); then compound 3.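

In this assay, taking the chloro away altogether gives a 1.3-fold lower number from compound 2 to compound 4 (0.10 log units; within the scatter), and taking the methyl away gives a 2.0-fold higher number from compound 1 to compound 4 (0.30 log units; within the scatter), so the bare pyridin-2-yl compound lies within the scatter of both substituted compounds. The earlier step between methyl and chloro showed that these two groups can be told apart, but this position does not need either of them for the number to stay in the same low range, and compound 4 cannot be ordered against compound 1 or compound 2. Nothing available explains why these steps are so small.

The compounds shown leave open how an amine, a methoxy group or a longer chain would read at this position. They also leave open whether hydrogen in place of chloro would be equally quiet on the core of compound 3.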